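Compound 2 to compound 3: losing the methyl

The source may report more compounds than this note shows. Statements on the series, on what has been measured and on what is new or still open speak of the compounds shown alone.

Measured in an ADME assay on microsomes from liver (Homo sapiens) for metabolic stability, read by LC-MS, with NADPH named in the record, with a stated time of 60 min, tested at 1 uM, in the absence of a further agent; on this read-out higher numbers stand for a more stable compound and lower numbers for a less stable compound:
- compound 1 `COc1ccc(-c2c(C)nc3c(N4CC[C@@H](NC(C)=O)C4)ccnn23)cc1OC`: > 95% (a limit of the assay)
- compound 2 `COc1ccc(-c2cnc3c(N4CC[C@@H](NC(C)=O)C4)cc(C)nn23)cc1OC`: > 95% (a limit of the assay)

In this assay compound 2 stands at > 95%, which is a limit and not a number. Compound 1 stands at > 95%, also a limit. Among the measured compounds shown here, the series so far therefore sits wholly at the limit of > 95% in this assay, at which 2 of the 2 values shown sit, and no measured step between compounds is available.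

The next compound is compound 3 `COc1ccc(-c2cnc3c(N4CC[C@@H](NC(C)=O)C4)ccnn23)cc1OC`. It carries hydrogen in place of methyl on an aromatic carbon of a six-membered aromatic ring with 2 nitrogen, next to the ring nitrogen (hydrogen in place of methyl on an aromatic carbon).

The expected step of a number at least 1 percentage points lower from compound 2 to compound 3 (that floor lies within the scatter) is estimated to stay within the usual scatter, and any movement is expected to be downward. This expectation rests only on compound 2 at > 95%, a limit.

For compound 3 the estimated value is 94%. The expected range for compound 3 runs from 82% to 100%.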

Compound 3, percent of the compound remaining: > 95%
Compound 3: no number, only a limit; the forecaster's own chance of this, stated with the estimate: 50%; middle value at least 1 percentage points away from the limit.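

In this assay compound 3 gives > 95%, a limit of the assay and not a number. No step from compound 1 or compound 2 to compound 3 can be read: the limit of > 95% in this assay, at which 3 of the 3 values shown sit.

The compounds shown leave open whether hydrogen in place of methyl changes the percent remaining in this assay at all.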